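The source may hold more compounds than are shown below. What is called first, only, known or untested is meant among the compounds shown, and "the series" means these compounds.

Measured in a functional assay (trachea) with Cavia porcellus as the target; a higher number here means that more compound is needed for the effect, a lower number that less compound is needed:
Compound 1 `C=CCCn1c(=O)c2[nH]cnc2n(CCC)c1=O`: 200 nM
Compound 2 `CCCn1c(=O)n(C)c(=O)c2c1ncn2CC(N)=O`: > 100000 nM

Compound 2 gives only a limit in this assay, (the limit of > 100000 nM in this assay, at which 1 of the 2 values shown sits), so no number is known for it. Within the data shown here, compound 1 gives 200 nM in this assay, and the two values show only that compound 1 has a measurable effect where compound 2 has not. Compound 3 `CCCn1c(=O)n(C)c(=O)c2c1ncn2CCCO` is not yet measured. It differs from compound 2 in one place: 2-hydroxyethyl in place of carbamoyl on a saturated chain carbon bound to an aromatic nitrogen. Among the measured compounds shown here, no measured step between two compounds is available to lean on, so the size of the step is uncertain. The exchange is small, and a large gain is not expected; the estimate for compound 3 in this assay is 40000 nM, between 5000 nM and 300000 nM, a step of an at least 2.5-fold lower number from compound 2 to compound 3 (0.39 log units; beyond the scatter) that is expected to be modest at best, with a real chance that only a limit is seen again.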

Compound 3, half-maximal effective concentration: 22600 nM
For compound 3 the middle estimate is 1.8-fold (0.25 log units) above the measured one; the range from low to high includes it.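

Compound 2 showed only a limit for this position. The chain on the aromatic nitrogen can also carry a group that gives a real number: in this assay, compound 3 reaches 22600 nM. Replacing carbamoyl with 2-hydroxyethyl on the saturated chain carbon bound to that nitrogen gives an at least 4.4-fold lower number from compound 2 to compound 3 (0.64 log units; beyond the scatter). The step may be larger than this, since compound 2 supplies a limit and not a number: the limit of > 100000 nM in this assay, at which 1 of the 3 values shown sits.

The change swaps the carbamoylmethyl group for 3-hydroxypropyl, so the chain and its end group differ together, and the step cannot be credited to either alone. A plain propyl chain, a 2-hydroxyethyl group with the hydroxyl on a shorter chain, or a chain ending in an amine or a carboxylic acid would help separate the two.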